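Swapping methylsulfonyl for fluoro on the pendant phenyl ring

The source may hold more compounds than are shown below. What is called first, only, known or untested is meant among the compounds shown, and "the series" means these compounds.

Compound 2 `CS(=O)(=O)c1ccc(-c2csc(N3N=C(c4ccc(Cl)s4)CC3c3ccc(F)cc3)n2)cc1` was tested in a functional assay on A549 cells (Homo sapiens) for antiproliferative activity, read by XTT assay, with a stated time of 24 h; a higher number here means a weaker inhibitor, a lower number a stronger inhibitor. In this assay compound 2 gives > 500 ug/mL, which is a limit of the assay rather than a number. Compound 4 `Fc1ccc(-c2csc(N3N=C(c4ccc(Cl)s4)CC3c3ccc(F)cc3)n2)cc1` has not yet been tested; it differs from compound 2 by fluoro in place of methylsulfonyl on an aromatic carbon. The closest guide is the reverse change seen elsewhere: compound 1 `Cc1ccc(C2=NN(c3nc(-c4ccc(F)cc4)cs3)C(c3ccc(F)cc3)C2)s1` gives 125 ug/mL in this assay, while compound 3 `Cc1ccc(C2=NN(c3nc(-c4ccc(S(C)(=O)=O)cc4)cs3)C(c3ccc(F)cc3)C2)s1` carries methylsulfonyl in place of fluoro. In this assay compound 3 gives > 500 ug/mL, again a limit. That pair shows an at least 4.0-fold higher number from compound 1 to compound 3 (0.60 log units; beyond the scatter), so fluoro in place of methylsulfonyl is expected to lower the number, meaning a stronger inhibitor. The comparison a step that the two limits leave unreadable from compound 2 to compound 3 cannot be sized, since both values sit at the limit of > 500 ug/mL in this assay, at which 2 of the 3 values shown sit. Compound 4 is therefore expected to land near compound 1, with an estimate of 150 ug/mL (range 60 ug/mL to 500 ug/mL), corresponding to an expected step of an at least 3.3-fold lower number from compound 2 to compound 4 (0.52 log units; beyond the scatter).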

Compound 4, half-maximal inhibitory concentration: > 500 ug/mL
Compound 4: no number, only a limit; the forecaster's own chance of this, stated with the estimate: 25%; middle value at least 3.3-fold (0.52 log units) away from the limit.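

With chloro rather than methyl elsewhere in the molecule, fluoro in place of methylsulfonyl yields no measurable number in this assay, so the gain seen in the methyl series does not carry over in any readable way. Chloro in place of methyl, with fluoro kept on the phenyl ring, gives an at least 4.0-fold higher number from compound 1 to compound 4 (0.60 log units; beyond the scatter), which shows that fluoro alone is not enough and that the group at the other end of the molecule matters too. The step between compound 2 and compound 4 cannot be read because both sit at a limit of the assay: the limit of > 500 ug/mL in this assay, at which 3 of the 4 values shown sit.

On these data alone, whether fluoro and methylsulfonyl differ at all when chloro is present stays open. Also open, as far as these compounds go, is whether another group in this place, such as an amine or a carboxylic acid, would give a number alongside chloro.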